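Changing the Aryl Group on the Ring Nitrogen

The source may report more compounds than this note shows. Statements on the series, on what has been measured and on what is new or still open speak of the compounds shown alone.

compound 1 `Oc1cc(C(F)(F)F)ccc1-c1nc(-c2ccccc2O)n(-c2ccc(I)cc2)n1` — 70.1%
compound 2 `Oc1cc(C(F)(F)F)ccc1-c1nc(-c2ccccc2O)n(-c2cccc(F)c2)n1` — 67.2%

In a functional assay on PC-12 cells (Rattus norvegicus) for cytotoxicity, read by MTT assay, with stated times of 2 h and 24 h, tested at 1 uM (on this read-out higher numbers stand for a stronger effect at the one concentration tested and lower numbers for a weaker effect), compound 1 gives 70.1% and compound 2 gives 67.2%. Compound 2 holds the smaller of the two numbers, but the step of a number 2.9 percentage points lower from compound 1 to compound 2 (within the scatter) lies within the scatter, so the two compounds cannot be told apart. Compound 3 `Oc1cc(C(F)(F)F)ccc1-c1nc(-c2ccccc2O)n(-c2ccc(Cl)cc2Cl)n1` differs from compound 2 by 2,4-dichlorophenyl in place of 3-fluorophenyl on an aromatic nitrogen. For the measured compounds named here, the only step that bears on this change is a number 2.9 percentage points lower from compound 1 to compound 2 (within the scatter), in which one aryl group replaced another on the same nitrogen without a shift beyond the scatter. No step beyond the scatter is therefore expected in this assay. Compound 3 is estimated at 68%, between 56% and 80%. The expected step is a number 0.8 percentage points higher from compound 2 to compound 3 (within the scatter).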

Compound 3, a percentage reported as activity, at one concentration (the size of the read-out at that concentration, not a potency): 69%
For compound 3 the middle estimate is 1 percentage points below the measured one; measured number inside the range.
By their numbers in this assay, from the lowest: compounds 2, 3 and 1 (each within the scatter of the next).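

For the compounds shown here, with a third aryl group on the aromatic nitrogen, this assay still separates no compounds: the data show a number 1.8 percentage points higher from compound 2 to compound 3 (within the scatter) and a number 1.1 percentage points lower from compound 1 to compound 3 (within the scatter) as the two new steps. The position thus accepts 2,4-dichlorophenyl, with its two chlorine atoms, as well as the single-halogen phenyl groups of compound 1 and compound 2, with no shift beyond the scatter. Nothing given here offers a reason for this result. The compounds shown carry only halogenated phenyl groups at this nitrogen, so it stays open whether an amine or a carboxylic acid on that phenyl ring, or a longer alkyl chain in its place, would move the number beyond the scatter.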